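This account rests on a few compounds, and the source may have more. Where it says the series, first, only, none or still open, it means among the compounds named here.

In a functional assay on cells (Homo sapiens) for antiproliferative activity, read by MTT assay, with a stated time of 48 h (a higher number here means a weaker inhibitor, a lower number a stronger inhibitor), compound 1 `CCN(CC)CCCn1c(N)c(-c2nc3ccccc3n2C)c2nc(C#N)c(C#N)nc21` gives 6750 nM, the higher of the two numbers measured, and compound 2 `CCN(CC)CCCCn1c(N)c(-c2nc3ccccc3n2C)c2nc(C#N)c(C#N)nc21` gives 2890 nM. Compound 3 `CCN(CC)CCCn1c(N)c(-c2nc3cc(Cl)ccc3[nH]2)c2nc(C#N)c(C#N)nc21` has not yet been measured. It keeps the 3-(diethylamino)propyl group of compound 1 and differs elsewhere: 5-chloro-1H-benzimidazol-2-yl in place of 1-methyl-1H-benzimidazol-2-yl on an aromatic carbon, with 5-chloro-1H-benzimidazol-2-yl in place of 1-methyl-1H-benzimidazol-2-yl on an aromatic carbon. Among the compounds with values here, the only measured step, a 2.3-fold lower number from compound 1 to compound 2 (0.37 log units; beyond the scatter), lies in the chain and not at this carbon, so it offers no direct guide and serves only as a rough measure of size. Within the data shown here, no measured compound carries the new group. A change of similar modest size is therefore expected, its direction uncertain, with a lower number tentatively favoured: the estimated step is a 2.3-fold lower number from compound 1 to compound 3 (0.35 log units; beyond the scatter). Compound 3 is expected at about 3000 nM, within an estimated range of 800 nM to 10000 nM.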

Compound 3, half-maximal inhibitory concentration: 23200 nM
Beside the measured number, compound 3's estimate is 7.7-fold (0.89 log units) below it, outside the stated range (above it).
By their numbers in this assay, from the lowest: compound 2; then compound 1; then compound 3.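

In this assay, the aromatic carbon next to the ring atom that bears an amino group proves sensitive to its substituent: 5-chloro-1H-benzimidazol-2-yl in place of 1-methyl-1H-benzimidazol-2-yl gives a 3.4-fold higher number from compound 1 to compound 3 (0.54 log units; beyond the scatter). Within the data shown here, this is a double change, since the entering group carries a chlorine and 1 hydrogen-bond donor, while the leaving group carries a methyl on nitrogen and 0 hydrogen-bond donors, and the single step cannot divide its size between them. Nothing measured on these compounds offers an explanation for the step.

From the compounds shown here alone, whether the chlorine or the loss of the methyl drives the step stays open, and 5-chloro-1-methyl-1H-benzimidazol-2-yl or unsubstituted 1H-benzimidazol-2-yl on the same carbon would separate the two. Also open, going by these compounds, is whether the longer chain of compound 2 would keep its step alongside 5-chloro-1H-benzimidazol-2-yl.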